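Replacing trifluoromethyl with phenyl in compound 2

A few compounds are considered here, and "the series" means these few. Any claim that something is new, unique, unknown or untested is made for them only; others in the source may bear on it.

- compound 1 `COc1ccc(-c2nc3sc(-c4ccccc4)cn3n2)cc1` gives 38%
- compound 2 `C/C(=N/O)c1ccc(NC(=O)Cn2nc(C(F)(F)F)nc2N)cc1` gives 15.1%
- compound 3 `COc1cc(-c2nc(N)n(CC(=O)Nc3ccc(/C(C)=N\O)cc3)n2)cc(OC)c1OC` gives 20.5%

In a functional assay on UO-31 cells (Homo sapiens) for inhibition, read by sulforhodamine B assay, with a stated time of 48 h, tested at 10 uM (a lower number here means less inhibition of growth, a higher number more inhibition of growth at the concentration tested), compound 2 (15.1%) lies within the scatter of compound 3 (20.5%), while compound 1 (38%) stands beyond the scatter above compound 2.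

Compound 4 `C/C(=N/O)c1ccc(NC(=O)Cn2nc(-c3ccccc3)nc2N)cc1` is still unmeasured and carries phenyl in place of trifluoromethyl on an aromatic carbon relative to compound 2. For the measured compounds named here, no measured pair isolates this change. Compound 3 (20.5%) also holds a six-membered aromatic ring of carbon only at that place and stays within the scatter of compound 2 (15.1%), so no step beyond the scatter is expected in this assay. The estimated step is small (a number 3.9 percentage points higher from compound 2 to compound 4 (within the scatter)). The expected value for compound 4 is 19% (range 9% to 32%).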

Compound 4, percent growth inhibition at one concentration: 15.4%
For compound 4 the middle estimate is 3.6 percentage points above the measured one; measured number inside the range.
By their numbers in this assay, from the lowest: compounds 2, 4 and 3 (each within the scatter of the next); then compound 1.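

In this assay, phenyl in place of trifluoromethyl on an aromatic carbon gives a number 0.3 percentage points higher from compound 2 to compound 4 (within the scatter). This is the only matched pair shown at this position, and it places an aromatic ring and trifluoromethyl there within the scatter of each other, so swapping these two groups does not separate the compounds. No data at hand offer an explanation for this result.

Still open, as far as these compounds go, is whether an amine or a carboxylic acid at this position would give a step beyond the scatter. The compounds shown also leave open whether a substituted phenyl would do so.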